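A few compounds are considered here, and "the series" means these few. Any claim that something is new, unique, unknown or untested is made for them only; others in the source may bear on it.

Measured in a physicochemical assay for solubility, read by spectrophotometry, measured as kinetic solubility, at pH 8, tested at 500 uM; a lower number here means a less soluble compound, a higher number a more soluble compound:
- compound 1 `Cn1cc(CNC(=O)c2ccncc2Nc2cc(-c3ccc4ccn(C)c4c3)c3nccnc3c2)cn1`: 127 ug/mL
- compound 2 `CC(=O)N1CCC(NC(=O)c2ccncc2Nc2cc(-c3ccc4ccn(C)c4c3)c3nccnc3c2)CC1`: 213 ug/mL
- compound 3 `Cn1ccc2ccc(-c3cc(Nc4cnccc4C(=O)NC4CCNC(=O)C4)cc4nccnc34)cc21`: 242 ug/mL

Compound 3 stands within the scatter of both other compounds, with a 1.9-fold higher number from compound 1 to compound 3 (0.28 log units; within the scatter) and a 1.1-fold higher number from compound 2 to compound 3 (0.06 log units; within the scatter). Compound 4 `CC(=O)N1CCCC(NC(=O)c2ccncc2Nc2cc(-c3ccc4ccn(C)c4c3)c3nccnc3c2)C1` differs from compound 3 by 1-acetylpiperidin-3-yl in place of 2-oxopiperidin-4-yl on an amide-type nitrogen. The closest evidence is the exchange of 1-acetylpiperidin-4-yl for 2-oxopiperidin-4-yl, a 1.1-fold higher number from compound 2 to compound 3 (0.06 log units; within the scatter). The remaining step, a 1.7-fold higher number from compound 1 to compound 2 (0.22 log units; within the scatter), is also within the scatter. Among the measured compounds shown here, no measured step exceeds the scatter, so no change beyond it is expected. The expected step is a 1.2-fold lower number from compound 3 to compound 4 (0.06 log units; within the scatter). For compound 4 the estimated value is 210 ug/mL, with an expected range of 130 ug/mL to 270 ug/mL.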

Compound 4, solubility: 212 ug/mL
Compound 4: middle estimate off by 1.0-fold (0.00 log units), on the low side, and the stated range covers the measured number.
By their numbers in this assay, from the lowest: compounds 1, 4, 2 and 3 (each within the scatter of the next).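

In this assay, 1-acetylpiperidin-3-yl in place of 1-acetylpiperidin-4-yl gives a 1.0-fold lower number from compound 2 to compound 4 (0.00 log units; within the scatter) and so adds a change of attachment point on the ring to the changes that stay within the scatter at this amide-type nitrogen. The other new steps, a 1.1-fold lower number from compound 3 to compound 4 (0.06 log units; within the scatter) and a 1.7-fold higher number from compound 1 to compound 4 (0.22 log units; within the scatter), are also within the scatter, so all four compounds remain unresolved by this read-out. No measurement shown accounts for these results. On these data alone, whether a primary amine or a carboxylic acid on this nitrogen would give a step beyond the scatter remains open.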